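Swapping 4-methylphenyl for 3,4-dichlorobenzyl on a sulfur

The source may report more compounds than this note shows. Statements on the series, on what has been measured and on what is new or still open speak of the compounds shown alone.

In a functional assay on DU-145 cells (Homo sapiens) for inhibition, read by trypan blue exclusion, with a stated time of 96 h (on this read-out lower numbers stand for stronger inhibition of growth and higher numbers for weaker inhibition of growth), compound 1 `Cc1ccc(CS/C(=C/c2c(O)cc(O)cc2O)C(=O)c2ccc(Cl)cc2)cc1` gives 50000 nM, and compound 2 `Cc1ccc(CS(=O)(=O)/C(=C/c2ccc(S(C)(=O)=O)cc2)C(=O)c2ccc(Br)cc2)cc1` gives 10000 nM. Compound 3 `COc1cc(OC)c(/C=C(/Sc2ccc(C)cc2)C(=O)c2ccc(Cl)cc2)c(OC)c1` reads > 100000 nM, which is a limit of the assay and not a number. Compound 3 is thus the only one of the three without a measured number. Compound 4 `COc1cc(OC)c(/C=C(/SCc2ccc(Cl)c(Cl)c2)C(=O)c2ccc(Cl)cc2)c(OC)c1` carries 3,4-dichlorobenzyl in place of 4-methylphenyl on a sulfur. Among the measured compounds shown here, no measured pair isolates this change. Compound 1, whose sulfur also bears a benzyl group, gives 50000 nM, so a measurable number is expected in this assay. The expected step of an at least 5.0-fold lower number from compound 3 to compound 4 (0.69 log units; beyond the scatter) is towards stronger inhibition of growth, beyond the scatter. For compound 4, the estimated value is 20000 nM, with an expected range of 3000 nM to 100000 nM.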

Compound 4, concentration for 50% growth inhibition: 10000 nM
Compound 4: middle estimate off by 2.0-fold (0.30 log units), on the high side, and the stated range covers the measured number.
By their numbers in this assay, from the lowest: compounds 2 and 4 (each within the scatter of the next); then compound 1. At a limit, above all of these: compound 3.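

In this assay, the group on this sulfur proves able to move the read-out: 3,4-dichlorobenzyl in place of 4-methylphenyl gives an at least 10-fold lower number from compound 3 to compound 4 (1.00 log units; beyond the scatter), towards stronger inhibition of growth. Among the compounds shown here, this is the first single-place comparison, and it takes the compound from a limit to a measured number. The step can be stated only as a bound, because compound 3 stands at a limit of the assay: the limit of > 100000 nM in this assay, at which 1 of the 4 values shown sits.

The single change combines a benzyl link with two chlorines, and the compounds shown do not separate these. From the compounds shown here alone, how a longer chain or an amine on this sulfur would read remains open.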